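The source may hold more compounds than are shown below. What is called first, only, known or untested is meant among the compounds shown, and "the series" means these compounds.

Compound 1 `O=C1CC[C@@H](C(=O)N2CCC(NS(=O)(=O)c3cc(S(=O)(=O)c4ccccc4)ccc3C(F)(F)F)CC2)N1` gives 90 nM in an assay on isolated protein for binding affinity to secreted frizzled-related protein 1 (Homo sapiens), read by fluorescence (a lower number here means a stronger inhibitor, a higher number a weaker inhibitor), the highest of the three numbers in hand. Compound 2 `CC(C)(C)NC(=O)N1CCC[C@H]1C(=O)N1CCC(NS(=O)(=O)c2cc(S(=O)(=O)c3ccccc3)ccc2C(F)(F)F)CC1` gives 20 nM, and compound 3 `O=C([C@@H]1CCCN1C(=O)Nc1ccccc1)N1CCC(NS(=O)(=O)c2cc(S(=O)(=O)c3ccccc3)ccc2C(F)(F)F)CC1` gives 20 nM. Compound 4 `O=C([C@@H]1CCCN1Cc1ccccc1)N1CCC(NS(=O)(=O)c2cc(S(=O)(=O)c3ccccc3)ccc2C(F)(F)F)CC1` awaits measurement; it differs from compound 1 in that (1-benzylpyrrolidin-2-yl in place of 5-oxopyrrolidin-2-yl on a carbonyl carbon). For the measured compounds named here, two measured steps bear on this. Exchanging the 5-oxopyrrolidin-2-yl for a substituted pyrrolidinyl gave a 4.5-fold lower number from compound 1 to compound 2 (0.65 log units; beyond the scatter), while swapping the group on the amide-type nitrogen gave no change at the digits printed from compound 2 to compound 3 (within the scatter). Going by the values given here, no measured compound carries a benzyl on the pyrrolidine nitrogen without a carbonyl, so the precedent is partial. Compound 4 is therefore expected to land at 35 nM, within 12 nM to 100 nM, which would mean a step of a 2.6-fold lower number from compound 1 to compound 4 (0.41 log units; beyond the scatter) in this assay.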

Compound 4, half-maximal inhibitory concentration: 1400 nM
For compound 4 the middle estimate is 40-fold (1.60 log units) below the measured one; the measured number lies above the stated range.
By their numbers in this assay, from the lowest: compounds 2 and 3 (each within the scatter of the next); then compound 1; then compound 4.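

In this assay, a substituted pyrrolidine nitrogen on this carbonyl carbon does not by itself give a lower number: benzyl in place of phenylcarbamoyl gives a 70-fold higher number from compound 3 to compound 4 (1.85 log units; beyond the scatter), and benzyl in place of (tert-butyl)carbamoyl gives a 70-fold higher number from compound 2 to compound 4 (1.85 log units; beyond the scatter). The 1-benzylpyrrolidin-2-yl group also falls behind the 5-oxopyrrolidin-2-yl group, with a 16-fold higher number from compound 1 to compound 4 (1.19 log units; beyond the scatter). No available evidence accounts for these steps.

The compounds shown leave open whether the loss follows the missing carbamoyl carbonyl or the benzyl group itself. A benzylcarbamoyl or acetyl group on that nitrogen would separate the two.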